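The compounds below may be only part of what the source reports. "The series", "measured", "known", "first", "only" and "open" are said of these compounds alone.

For the measured compounds named here, the three compounds measured so far share one core and differ at the amine. In an ADME assay for permeability, using PAMPA, at pH 7.4 (a lower number here means that the compound crosses the layer more slowly, a higher number that the compound crosses the layer faster), compound 1 `CCCN(C[C@H]1Cc2c(cccc2N2CCNCC2)CN1)[C@H]1CCCc2cccnc21` gives 26.5 nm/s. Compound 2 `c1cnc2c(c1)CCC[C@@H]2N(CC1CC1)C[C@H]1Cc2c(cccc2N2CCNCC2)CN1` gives 87 nm/s in this assay, and compound 3 `Cc1cnc2c(c1)CCC[C@@H]2N(C)C[C@H]1Cc2c(cccc2N2CCNCC2)CN1` gives 9 nm/s. Compound 2 therefore stands highest of the three numbers in this assay: the nearest is compound 1, and compound 3 lies furthest below it. Compound 3 differs from the others in two places at once, so its value is reported without a step. Going by the values given here, the one single-point step in the set, a 3.3-fold higher number from compound 1 to compound 2 (0.52 log units; beyond the scatter), runs upward.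

The next compound, compound 4 `c1cnc2c(c1)CCC[C@@H]2N(CC1CCCCC1)C[C@H]1Cc2c(cccc2N2CCNCC2)CN1`, differs from compound 2 by cyclohexyl in place of cyclopropyl on a saturated chain carbon bound to an amine nitrogen. Among the compounds with values here, the only measured step that bears on this change is a 3.3-fold higher number from compound 1 to compound 2 (0.52 log units; beyond the scatter), where a larger saturated carbon ring replaced a chain on the same position and the number in this assay rose. Within the data shown here, that step is the basis for expecting compound 4 to move in the same direction, by a modest amount, with the size uncertain since no measured step covers a ring as large as cyclohexyl. Compound 4 is thus expected to give 150 nm/s in this assay, estimated to fall between 60 nm/s and 350 nm/s. The expected step for compound 4 is a 1.7-fold higher number from compound 2 to compound 4 (0.24 log units; within the scatter).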

Compound 4, apparent permeability: 9 nm/s
Compound 4: middle estimate off by 17-fold (1.22 log units), on the high side, outside the stated range (below it).
By their numbers in this assay, from the lowest: compounds 3 and 4 (each within the scatter of the next); then compound 1; then compound 2.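

In this assay, this position does not reward a larger saturated carbon ring in any simple way: the change to cyclohexyl gives a fall (a 9.7-fold lower number from compound 2 to compound 4 (0.99 log units; beyond the scatter)), which runs against the earlier rise on going from the open chain to cyclopropyl (a 3.3-fold higher number from compound 1 to compound 2 (0.52 log units; beyond the scatter)). Cyclohexyl also ends up under the open chain (a 2.9-fold lower number from compound 1 to compound 4 (0.47 log units; beyond the scatter)), so among compounds 1, 2 and 4, with steps between them all beyond the scatter, cyclopropyl gives the highest number and cyclohexyl the lowest, and the read-out at this place goes up and then down rather than following ring size in one direction. Nothing among the data shown explains this reversal.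

The compounds shown leave open where between cyclopropyl and cyclohexyl the number turns, a question that cyclobutyl or cyclopentyl at the same place would address. They also leave open whether the high number belongs to small rings in general or to cyclopropyl alone, which a longer chain or an isopropyl group on the same carbon could help to separate.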